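The source may report more compounds than this note shows. Statements on the series, on what has been measured and on what is new or still open speak of the compounds shown alone.

Measured compounds and values:
- compound 1 `O=S(=O)(/C=C/c1ncccc1F)c1cccc(F)c1` — 474 nM
- compound 2 `O=S(=O)(/C=C/c1ncccc1Cl)c1cccc(F)c1` — 84 nM

In an assay on U2OS cells for activation of nuclear factor erythroid 2-related factor 2 (Homo sapiens), read by beta-arrestin recruitment, with a stated time of 6 h (a lower number here means that less compound is needed, a higher number that more compound is needed for the effect), compound 1 gives 474 nM, and compound 2 gives 84 nM. Within the data shown here, compound 2 thus stands at the lowest of the two numbers in this assay; its nearest neighbour is compound 1, and the single measured step, a 5.6-fold lower number from compound 1 to compound 2 (0.75 log units; beyond the scatter), is beyond the scatter.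

The next compound is compound 3 `O=S(=O)(/C=C\c1ncccc1Cl)c1cccc(F)c1`. Its relation to compound 2: the two compounds have the same atoms and bonds and differ only in configuration as drawn: 1 of 1 stereo elements differ; a double bond is drawn E in compound 2 and Z in compound 3. Among the measured compounds shown here, the measured step concerns a halogen exchange on an aromatic carbon and says nothing about the configuration of the double bond, so no measured step bears on the change from compound 2 to compound 3. The expectation must rest on the observation that compound 2 gives 84 nM and that an unmeasured kind of change is made; a change in configuration is expected to alter the number, with a higher number considered more likely than a lower one, but the direction is not secured by any measurement here.

Compound 3 is therefore estimated at 250 nM in this assay, within a wide range from 60 nM to 1000 nM, which corresponds to an expected step of a 3.0-fold higher number from compound 2 to compound 3 (0.47 log units; beyond the scatter).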

Compound 3, half-maximal effective concentration: 2160 nM
Compound 3: the middle estimate sits 8.6-fold (0.94 log units) below what was measured; measured number outside the range, above it.
By their numbers in this assay, from the lowest: compound 2; then compound 1; then compound 3.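

In this assay, the configuration of the double bond proves to be a major determinant of the number, not a minor detail of the drawing: a 26-fold higher number from compound 2 to compound 3 (1.41 log units; beyond the scatter). With no atom entering or leaving, the whole of this step can be assigned to the configuration as drawn, because nothing else separates the pair: the fact that compounds 2 and 3 differ only in the configuration as drawn. The earlier compounds shown here, both drawn E, could show only the halogen exchange, a 5.6-fold lower number from compound 1 to compound 2 (0.75 log units; beyond the scatter), and the change from E to Z gives the larger of the two steps, with the E form carrying the lower number in this pair.

Going by these compounds, the configuration step rests on this one pair, so it remains open whether it carries over to the fluoro analogue, compound 1, or to a bromo, methoxy or nitrile group in place of the chloro. Also open, on these data alone, is how the number responds when a saturated chain replaces the double bond, or when an amine or a carboxylic acid is added to the shared core.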